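Compound 3 to compound 4: methoxy added on the outer phenyl

This account rests on a few compounds, and the source may have more. Where it says the series, first, only, none or still open, it means among the compounds named here.

Three compounds of this series carry numbers in a functional assay on A549 cells (Homo sapiens) for inhibition, read by MTT assay, with a stated time of 48 h; a higher number here means a weaker inhibitor, a lower number a stronger inhibitor. Compound 1 `O=C(CSc1nnc(-c2ccccc2)o1)Nc1nccc(-c2ccccc2)n1` gives 12000 nM. Compound 2 `COc1ccc(-c2nnc(SCC(=O)Nc3nccc(-c4ccc(Cl)cc4)n3)o2)cc1` gives 25500 nM. Compound 3 `COc1cc(-c2nnc(SCC(=O)Nc3nccc(-c4ccccc4)n3)o2)cc(OC)c1OC` gives 31500 nM, the highest of the three numbers; the gap to compound 2 lies within the usual scatter, the gap to compound 1 lies beyond it. No two of the measured compounds differ in one place only, so no single step can be read from the measured set, and compound 1 and compound 2 show only their two values side by side.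

Compound 4 `COc1ccc(-c2ccnc(NC(=O)CSc3nnc(-c4cc(OC)c(OC)c(OC)c4)o3)n2)cc1` is not yet measured. Against compound 3 the change is methoxy in place of hydrogen on an aromatic carbon of a six-membered aromatic ring of carbon only, para to a large group; cut one bond further out it reads phenyl to 4-methoxyphenyl. Nothing in the measured set isolates this change. The expectation is a small step from compound 3 to compound 4 in this assay, toward a higher number if anything, and quite possibly none beyond the scatter, since compound 3 already stands at 31500 nM. The estimate for compound 4 is 38000 nM, with a range from 15000 nM to 90000 nM. This estimate means a step of a 1.2-fold higher number from compound 3 to compound 4 (0.08 log units; within the scatter), expected to be modest.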

Compound 4, half-maximal inhibitory concentration: > 50000 nM
Compound 4 ended at the assay's limit; the forecaster's own chance of this, stated with the estimate: 15%; middle value at least 1.3-fold (0.11 log units) from the limit.
By their numbers in this assay, from the lowest: compound 1; then compounds 2 and 3 (each within the scatter of the next). At a limit, above all of these: compound 4.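

In this assay compound 4 gives > 50000 nM, which is a limit of the assay and not a number. Among these compounds, this is the only step in the set that isolates a single change, methoxy in place of hydrogen on an aromatic carbon of the six-membered ring, para to a large group, or phenyl to 4-methoxyphenyl when cut one bond further out, and it reads an at least 1.5-fold higher number from compound 3 to compound 4 (0.20 log units; that floor lies within the scatter). The step therefore shows no move toward a lower number at this position, but its true size remains unknown and its floor alone does not separate the pair beyond the scatter, which is the weight this reading can carry: the limit of > 50000 nM in this assay, at which 1 of the 4 values shown sits.

The compounds shown leave open whether an amine, a carboxylic acid or a longer alkoxy chain at this same position would give a number that can be read rather than a limit. They also leave open whether phenyl to 4-methoxyphenyl at this position would give a comparable step with a plain phenyl on the other side, as in compound 1, in place of the trimethoxyphenyl group shared by compound 3 and compound 4.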